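Series notes: the step from compound 3 to compound 4

The source may hold more compounds than are shown below. What is called first, only, known or untested is meant among the compounds shown, and "the series" means these compounds.

compound 1 `O=c1cc(N2CCNCC2)c2c(OCc3ccccc3)cccc2o1`: 187000 nM
compound 2 `O=c1cc(N2CCNCC2)c2ccc(OCc3cccnc3)cc2o1`: 21300 nM
compound 3 `COCOc1ccc2c(N3CCNCC3)cc(=O)oc2c1C`: 2300 nM

In a functional assay on a cell-free system (plasma, Homo sapiens) for inhibition, with Plasma (Rattus norvegicus) as the target (on this read-out lower numbers stand for stronger inhibition and higher numbers for weaker inhibition), compound 3 stands lowest of the three at 2300 nM, and the gaps to the other two lie beyond the scatter. Compound 4 `Cc1c(OCCOc2ccccc2)ccc2c(N3CCNCC3)cc(=O)oc12` carries phenoxymethyl in place of methoxy on a saturated chain carbon bound to an oxygen on an aromatic ring. Among the compounds with values here, no measured pair differs in one place, so the size of this step has no direct support. Compound 2 at 21300 nM and compound 1 at 187000 nM offer only a weak hint of direction. In this assay the expected change is moderate and toward weaker inhibition, an estimated 2.6-fold higher number from compound 3 to compound 4 (0.42 log units; beyond the scatter). For compound 4 the estimated value is 6000 nM, with an expected range of 1200 nM to 35000 nM.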

Compound 4, half-maximal inhibitory concentration: 9400 nM
Compound 4: middle estimate off by 1.6-fold (0.19 log units), on the low side; the measured number falls inside the stated range.
By their numbers in this assay, from the lowest: compound 3; then compound 4; then compound 2; then compound 1.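

In this assay, within the data shown here, replacing methoxy with phenoxymethyl on a saturated chain carbon bound to an oxygen on an aromatic ring gives this position its only direct reading, toward weaker inhibition (a 4.1-fold higher number from compound 3 to compound 4 (0.61 log units; beyond the scatter)). The position therefore takes the added six-membered aromatic ring at a modest cost, and compound 4 keeps measurable inhibition. No evidence on hand accounts for this step. Still open, from the compounds shown here alone, is how an amine or a carboxylic acid in place of phenoxymethyl would read here, and whether a longer chain would widen or narrow the step.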